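The source may report more compounds than this note shows. Statements on the series, on what has been measured and on what is new or still open speak of the compounds shown alone.

Compound 2, whose structure is `C=C1CC[C@@H]2[C@](C)(CNCc3ccc([N+](=O)[O-])cc3)[C@H](O)CC[C@@]2(C)[C@@H]1/C=C/C1=CCOC1=O`, gives 1340 nM in a functional assay on BMMC cells (Mus musculus, strain C57BL/6) for inhibition, with stated times of 5 days and 48 h; on this read-out lower numbers stand for stronger inhibition and higher numbers for weaker inhibition. Among the measured compounds shown here, of the two compounds measured so far it holds the highest number; its only neighbour is compound 1, `C=C1CC[C@@H]2[C@](C)(CNCc3ccc(Br)cc3)[C@H](O)CC[C@@]2(C)[C@@H]1/C=C/C1=CCOC1=O`, which in this assay gives 430 nM. For the measured compounds named here, the single measured step between them, a 3.1-fold higher number from compound 1 to compound 2 (0.49 log units; beyond the scatter), tells what the exchange of one substituent on the aromatic ring did on the shared core.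

Compound 3, `C=C1CC[C@@H]2[C@](C)(CNCc3ccncc3)[C@H](O)CC[C@@]2(C)[C@@H]1/C=C/C1=CCOC1=O`, is not yet measured. It differs from compound 2 in one place: pyridin-4-yl in place of 4-nitrophenyl on a saturated chain carbon bound to an amine nitrogen. Going by the values given here, no measured step covers this particular exchange; the step from compound 1 to compound 2 concerns a different pair of substituents on the same ring and so offers only a loose guide to how much the read-out moves when that part of the molecule is altered. Given that, the reasonable expectation for compound 3 in this assay is a number close to that of compound 2, perhaps somewhat lower, with the expected step being a 1.5-fold lower number from compound 2 to compound 3 (0.17 log units; within the scatter). Compound 3 is therefore estimated at 900 nM, with a range from 300 nM to 2700 nM.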

Compound 3, half-maximal inhibitory concentration: 2030 nM
Compound 3: middle estimate off by 2.3-fold (0.35 log units), on the low side; measured number inside the range.
By their numbers in this assay, from the lowest: compound 1; then compounds 2 and 3 (each within the scatter of the next).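

The exchange of 4-nitrophenyl for pyridin-4-yl on a saturated chain carbon bound to an amine nitrogen gives a 1.5-fold higher number from compound 2 to compound 3 (0.18 log units; within the scatter) in this assay, so at this place the ring with one hetero atom and the 4-nitrophenyl ring read alike within the scatter. Set against 4-bromophenyl, pyridin-4-yl gives a 4.7-fold higher number from compound 1 to compound 3 (0.67 log units; beyond the scatter), and together with a 3.1-fold higher number from compound 1 to compound 2 (0.49 log units; beyond the scatter) this makes compound 1 the strongest inhibitor of the three, with the change from its 4-bromophenyl group moving the number upward for both groups that replace it. Nothing available bears on what lies behind these differences.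

The compounds shown leave open whether the bromo substituent matters in its own right, since they offer no comparison with an unsubstituted phenyl, a 4-chlorophenyl or a 4-methoxyphenyl group at this place. They also leave open how pyridin-4-yl compares with pyridin-3-yl or pyridin-2-yl, and whether a longer chain between the amine nitrogen and the ring would shift the read-out.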